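Cytotoxicity notes: hydroxyethyl replaces chlorophenyl at the triazole nitrogen chain

The source may report more compounds than this note shows. Statements on the series, on what has been measured and on what is new or still open speak of the compounds shown alone.

Compound 1, `Cc1ccc(Cn2cc(CNC(=O)c3cnc(Nc4ccc(C#N)cc4)cc3Oc3c(C)cc(C)cc3C)nn2)cc1`, in an ADME assay on MT4 cells (Homo sapiens) for cytotoxicity, read by MTT assay, with a stated time of 5 days (a lower number here means that less compound is tolerated, a higher number that more compound is tolerated), gives 165000 nM.
Compound 2, `Cc1cc(C)c(Oc2cc(Nc3ccc(C#N)cc3)ncc2C(=O)NCc2cn(Cc3ccccc3Cl)nn2)c(C)c1`, gives in this assay only a limit, >= 188000 nM.
Compound 3, `Cc1cc(C)c(Oc2cc(Nc3ccc(C#N)cc3)ncc2C(=O)NCc2cn(Cc3ccc(Cl)cc3)nn2)c(C)c1`, gives in this assay likewise only a limit, >= 120000 nM.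

Compound 3 therefore stands at the limit of >= 120000 nM in this assay, at which 1 of the 3 values shown sits; one further value sits at the limit of >= 188000 nM in this assay, at which 1 of the 3 values shown sits, so no number is known for it. Compound 4, `Cc1cc(C)c(Oc2cc(Nc3ccc(C#N)cc3)ncc2C(=O)NCc2cn(CCCO)nn2)c(C)c1`, differs from compound 3 by 2-hydroxyethyl in place of 4-chlorophenyl on a saturated chain carbon bound to an aromatic nitrogen. Of the measured steps, only an at least 1.1-fold higher number from compound 1 to compound 2 (0.05 log units; that floor lies within the scatter) has a readable size, and it lies within the scatter; a step that the two limits leave unreadable from compound 2 to compound 3 and a step that the limit leaves unreadable from compound 1 to compound 3 are left unreadable by the limits. For the measured compounds named here, the one readable step at this position is within the scatter, so the expected step is a step that the limit leaves unreadable from compound 3 to compound 4, none beyond the scatter. Compound 4 is estimated at 150000 nM, between 60000 nM and 350000 nM, with a fair chance that only a limit is reported.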

Compound 4, half-maximal cytotoxic concentration: 25200 nM
Compound 4: middle estimate off by 6.0-fold (0.77 log units), on the high side; the whole stated range lies above it.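

In this assay, for the compounds shown here, the earlier aromatic groups at this position gave no step readable beyond the scatter, whereas the change to 2-hydroxyethyl does: a 6.5-fold lower number from compound 1 to compound 4 (0.82 log units; beyond the scatter) is a full reading, while an at least 4.7-fold lower number from compound 3 to compound 4 (0.67 log units; beyond the scatter) and an at least 7.4-fold lower number from compound 2 to compound 4 (0.87 log units; beyond the scatter) are floors set by limits. The group on this chain carbon therefore matters for how much compound is tolerated.

The compounds shown do not separate loss of the aromatic ring from entry of the hydroxyl. A plain alkyl chain, an amine or a carboxylic acid here would help to separate the two.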